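A Nitrile in Place of the Pyrazole

The source may report more compounds than this note shows. Statements on the series, on what has been measured and on what is new or still open speak of the compounds shown alone.

Of the compounds shown here, two sharing one core have been measured in a functional assay for inhibition of sodium/hydrogen exchanger (Oryctolagus cuniculus); on this read-out lower numbers stand for stronger inhibition and higher numbers for weaker inhibition. Compound 1 `Cc1cc(OCc2ccccc2)c(S(C)(=O)=O)cc1C(=O)N=C(N)N` gives 28 nM in this assay . Compound 2 `Cc1cc(-n2cccn2)c(S(C)(=O)=O)cc1C(=O)N=C(N)N` gives 25 nM in this assay . Among the compounds with values here, the only step between them, a 1.1-fold lower number from compound 1 to compound 2 (0.05 log units; within the scatter), shows that exchanging the benzyloxy group for the pyrazolyl group at this position left the read-out essentially unchanged, so compound 2 and compound 1 stand within the usual scatter of each other and neither can be ranked above the other.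

The next compound, compound 3 `Cc1cc(C#N)c(S(C)(=O)=O)cc1C(=O)N=C(N)N`, has not yet been measured. It differs from compound 2 as follows: cyano in place of 1H-pyrazol-1-yl on an aromatic carbon.

Within the data shown here, the single measured step, the change from benzyloxy to pyrazolyl, bears on this position and was within the scatter. Among the measured compounds shown here, no measured step involves the cyano group itself, so its effect is unknown. Given that the one step at this position, a 1.1-fold lower number from compound 1 to compound 2 (0.05 log units; within the scatter), was small, compound 3 is expected to change this assay by a 1.4-fold higher number from compound 2 to compound 3 (0.15 log units; within the scatter), a step not clearly beyond the scatter. Compound 3 is therefore estimated at 35 nM in this assay , with a range from 12 nM to 110 nM.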

Compound 3, half-maximal inhibitory concentration: 70 nM
Beside the measured number, compound 3's estimate is 2.0-fold (0.30 log units) below it; low and high end bracket the measured number.
By their numbers in this assay, from the lowest: compounds 2 and 1 (each within the scatter of the next); then compound 3.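

The position ortho to a methylsulfonyl group had shown no readable difference between benzyloxy and 1H-pyrazol-1-yl, but the cyano group shows that the group on this aromatic carbon can matter in this assay. Cyano in place of 1H-pyrazol-1-yl gives a 2.8-fold higher number from compound 2 to compound 3 (0.45 log units; beyond the scatter), and cyano in place of benzyloxy gives a 2.5-fold higher number from compound 1 to compound 3 (0.40 log units; beyond the scatter), so both steps are modest but beyond the scatter, and compound 3 stands apart from the pair of compound 1 and compound 2. Nothing in the data given here accounts for this shift.

With only three groups at this position, the compounds shown cannot tell whether the higher number belongs to cyano in particular or would also come with other groups that lack a ring, such as a methoxy, an amine or a single fluorine. They also leave open how far the position would accept a longer chain, or a carboxylic acid, on this aromatic carbon.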